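Open-chain amine in place of the thiazolidine ring

The source may hold more compounds than are shown below. What is called first, only, known or untested is meant among the compounds shown, and "the series" means these compounds.

Of the compounds shown here, three sharing one core have been measured in a functional assay on PBMC cells (Homo sapiens) for inhibition; a higher number here means a weaker inhibitor, a lower number a stronger inhibitor. Compound 1 `CC[C@H](C)[C@H](N)C(=O)NS(=O)(=O)OC[C@H]1O[C@@H](n2cnc3c(N)ncnc32)[C@H](O)[C@@H]1O` gives 5600 nM, and compound 2 `CCC[C@H](N)C(=O)NS(=O)(=O)OC[C@H]1O[C@@H](n2cnc3c(N)ncnc32)[C@H](O)[C@@H]1O` gives 4700 nM; the step of a 1.2-fold lower number from compound 1 to compound 2 (0.08 log units; within the scatter) is within the scatter. Compound 3 `Nc1ncnc2c1ncn2[C@@H]1O[C@H](COS(=O)(=O)NC(=O)[C@@H]2CSCN2)[C@@H](O)[C@H]1O` gives 550 nM, the lowest of the three numbers, and both of its steps to the others are beyond the scatter: a 10-fold lower number from compound 1 to compound 3 (1.01 log units; beyond the scatter) and an 8.5-fold lower number from compound 2 to compound 3 (0.93 log units; beyond the scatter).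

Compound 4 `CSCC[C@H](N)C(=O)NS(=O)(=O)OC[C@H]1O[C@@H](n2cnc3c(N)ncnc32)[C@H](O)[C@@H]1O` has not yet been measured in this assay. It differs from compound 3 in one place: 1-amino-3-(methylsulfanyl)propyl in place of 1,3-thiazolidin-4-yl on a carbonyl carbon. The group that enters is an open chain bearing an amino group, as in compound 1 and compound 2, rather than the five-membered ring of compound 3. The two steps that bear on this change are those from the open-chain compounds to compound 3, and both run in the same direction and with similar size. Reversing them, compound 4 is expected to return toward the numbers of compound 1 and compound 2, with a step of an 8.2-fold higher number from compound 3 to compound 4 (0.91 log units; beyond the scatter) that should lie beyond the scatter. Compound 4 is therefore estimated at 4500 nM, with a range from 1500 nM to 14000 nM.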

Compound 4, half-maximal inhibitory concentration: 500 nM
Estimate against measurement, compound 4: 9.0-fold (0.95 log units) above; measured number outside the range, below it.
By their numbers in this assay, from the lowest: compounds 4 and 3 (each within the scatter of the next); then compounds 2 and 1 (each within the scatter of the next).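

In this assay, the step of a 1.1-fold lower number from compound 3 to compound 4 (0.04 log units; within the scatter) shows that an open chain bearing an amino group on this carbonyl carbon does not by itself bring back the higher numbers of compound 1 and compound 2, and that the ring of compound 3 is not needed to reach this range. What separates the open-chain compounds is the chain itself: 2-(methylsulfanyl)ethyl in place of sec-butyl gives an 11-fold lower number from compound 1 to compound 4 (1.05 log units; beyond the scatter), and methylsulfanyl in place of methyl gives a 9.4-fold lower number from compound 2 to compound 4 (0.97 log units; beyond the scatter), while the step between the two chains without sulfur stayed within the scatter. No measurement is at hand that would explain these steps.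

The compounds shown leave open whether the step goes with the sulfur atom or with the added chain length, and a methoxy or an ethyl group in place of methylsulfanyl would separate the two. They also leave open how far the sulfur tolerates change, as with a sulfoxide or a sulfone at that point in the chain.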